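Ethoxy to 2,2,2-trifluoroethyl on the shared core

This account rests on a few compounds, and the source may have more. Where it says the series, first, only, none or still open, it means among the compounds named here.

In an ADME assay on microsomes from liver (Rattus norvegicus, strain Sprague-Dawley) for metabolic stability, read by HPLC, using NADPH, with stated times of 5 min and 60 min, tested at 10 uM (on this read-out higher numbers stand for fast clearance and lower numbers for slow clearance), compound 2 `CCOc1ccc(C(=O)NCc2ccc(NS(C)(=O)=O)cc2Cl)cc1` gives 12 mL.min-1.g-1 and stands within the scatter of compound 1 `CS(=O)(=O)Nc1ccc(CNC(=O)c2ccc(N3CCCC3)cc2)c(Cl)c1` at 17 mL.min-1.g-1 on the same read-out. Compound 3 `CS(=O)(=O)Nc1ccc(CNC(=O)c2ccc(CC(F)(F)F)cc2)c(Cl)c1` carries 2,2,2-trifluoroethyl in place of ethoxy on an aromatic carbon. Going by the values given here, only one measured step bears on this, namely a 1.4-fold lower number from compound 1 to compound 2 (0.15 log units; within the scatter) at the same carbon, and it lies within the scatter. Among the compounds with values here, no measured compound carries 2,2,2-trifluoroethyl, so the expectation is loose, and no step beyond the scatter is expected in this assay in either direction. The estimated step is no change at the digits printed from compound 2 to compound 3 (within the scatter) and stays within the scatter. For compound 3 the estimated value is 12 mL.min-1.g-1 (range 5 mL.min-1.g-1 to 25 mL.min-1.g-1).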

Compound 3, intrinsic clearance in microsomes: 22 mL.min-1.g-1
Compound 3: middle estimate off by 1.8-fold (0.26 log units), on the low side; low and high end bracket the measured number.
By their numbers in this assay, from the lowest: compounds 2, 1 and 3 (each within the scatter of the next).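

In this assay, 2,2,2-trifluoroethyl in place of ethoxy gives a 1.8-fold higher number from compound 2 to compound 3 (0.26 log units; within the scatter), and in place of pyrrolidin-1-yl it gives a 1.3-fold higher number from compound 1 to compound 3 (0.11 log units; within the scatter). This aromatic carbon, para to a large group, thus now carries three different groups, including one with 0 hydrogen-bond acceptors against 1 for ethoxy, and all three compounds stay within the scatter of one another. Nothing at hand accounts for these numbers.

From the compounds shown here alone, whether a carboxylic acid or a primary amine at this carbon would stay within that scatter remains open. So does whether a longer chain would.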